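Furan-2-yl in place of 1,3-thiazol-2-yl

The source may hold more compounds than are shown below. What is called first, only, known or untested is meant among the compounds shown, and "the series" means these compounds.

Compound 1 `CCOC(=O)/C=C/C=C/C=C/c1ccc[nH]1` gives 3670 nM
Compound 2 `CCOC(=O)/C=C/C=C/C=C/C=C/C=C/c1ccc[nH]1` gives 450 nM
Compound 3 `CCOC(=O)/C=C/C=C/C=C/c1nccs1` gives 4500 nM

In a functional assay on CCRF-CEM cells (Homo sapiens) for cytotoxicity, with a stated time of 72 h (a higher number here means a weaker inhibitor, a lower number a stronger inhibitor), compound 3 gives 4500 nM and so sits level with compound 1 within the usual scatter. Compound 2 reads clearly lower (450 nM), which in this read-out means a stronger inhibitor.

The next structure is compound 4 `CCOC(=O)/C=C/C=C/C=C/c1ccco1`, made from compound 3 by putting furan-2-yl in place of 1,3-thiazol-2-yl on a double-bonded chain carbon bound to a double-bonded chain carbon.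

Within the data shown here, only one measured step bears on this change: 1,3-thiazol-2-yl in place of 1H-pyrrol-2-yl at that same place gave a 1.2-fold higher number from compound 1 to compound 3 (0.09 log units; within the scatter) and stayed within the scatter. Among the measured compounds shown here, no compound with furan-2-yl has a value yet, so this guide is thin. Because of a 1.2-fold higher number from compound 1 to compound 3 (0.09 log units; within the scatter) no step beyond the scatter is expected in this assay here. The estimated step is small (a 1.1-fold lower number from compound 3 to compound 4 (0.05 log units; within the scatter)). Compound 4 is expected at 4000 nM (estimated range 1800 nM to 9000 nM).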

Compound 4, half-maximal inhibitory concentration: > 10000 nM
Compound 4: a limit, no number; the forecaster's own chance of this, stated with the estimate: 3%; middle value at least 2.5-fold (0.39 log units) from the limit.
By their numbers in this assay, from the lowest: compound 2; then compounds 1 and 3 (each within the scatter of the next). At a limit, above all of these: compound 4.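

In this assay, compound 4 gives > 10000 nM, which is a limit of the assay and not a number. The earlier compounds shown here suggested that the ring at this place could be exchanged freely, since the swap of 1H-pyrrol-2-yl for 1,3-thiazol-2-yl gave a 1.2-fold higher number from compound 1 to compound 3 (0.09 log units; within the scatter), but furan-2-yl brings an at least 2.2-fold higher number from compound 3 to compound 4 (0.34 log units; beyond the scatter) and an at least 2.7-fold higher number from compound 1 to compound 4 (0.43 log units; beyond the scatter). So this position does respond to the choice of five-membered aromatic ring, even though 1,3-thiazol-2-yl and furan-2-yl have the same count of heavy atoms, and the true size of both new steps remains unknown.

On these data alone, whether a thiophen-2-yl or a phenyl group at this place would read like compound 3 or like compound 4 remains open. Also open, as far as these compounds go, is whether the longer chain of compound 2 would keep its lower number with furan-2-yl attached.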